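The source may report more compounds than this note shows. Statements on the series, on what has been measured and on what is new or still open speak of the compounds shown alone.

Measured so far:
compound 1 `C=CS(=O)(=O)N1CCN(c2ncnc3sc(-c4ccc(C(F)(F)F)cc4)cc23)CC1` — 7080 nM
compound 2 `C=CS(=O)(=O)N1CCN(c2nc(OC[C@H]3CCCN3C)nc3sc(-c4ccc(N5CCN(C)CC5)cc4)cc23)[C@@H](C)C1` — 1920 nM
compound 3 `CN1CCN(c2ccc(-c3cc4c(N5CCN(S(=O)(=O)/C=C/c6ccccc6)CC5)ncnc4s3)cc2)CC1` — 8670 nM

All three numbers come from a functional assay on MDA-MB-436 cells (Homo sapiens) for antiproliferative activity, read by MTT assay, with a stated time of 48 h; a lower number here means a stronger inhibitor, a higher number a weaker inhibitor. Compound 3 has the highest of the three numbers. Its nearest neighbour is compound 1, which gives 7080 nM, a gap within the usual scatter, so the two are not separated by this assay. Compound 2 is the furthest from it and gives 1920 nM, a lower number that lies beyond the scatter.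

Compound 4 `COc1ccccc1NC(=O)N1CCN(c2ncnc3sc(-c4ccc(N5CCN(C)CC5)cc4)cc23)CC1` is not yet measured in this assay. It differs from compound 3 in one place: (2-methoxyphenyl)carbamoyl in place of (2-phenylethenyl)sulfonyl on an amine nitrogen in a ring. For the measured compounds named here, no step between measured compounds covers this kind of change; each of the three measured compounds carries a sulfonyl group on that ring nitrogen, and compound 4 carries a carbamoyl group instead, so nothing measured bears directly on the exchange.

Going by the values given here, with no comparable step to lean on, the expectation for compound 4 is a number close to that of compound 3, with no step beyond the scatter clearly supported in either direction; the estimated step is a 1.4-fold higher number from compound 3 to compound 4 (0.14 log units; within the scatter). Compound 4 is thus expected to give about 12000 nM in this assay, in the range 4000 nM to 40000 nM.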

Compound 4, half-maximal inhibitory concentration: 26300 nM
For compound 4 the middle estimate is 2.2-fold (0.34 log units) below the measured one, and the stated range covers the measured number.
By their numbers in this assay, from the lowest: compound 2; then compounds 1 and 3 (each within the scatter of the next); then compound 4.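

For the compounds shown here, on the amine nitrogen in the ring, this is the first exchange in this assay that can be read directly, and it gives a 3.0-fold higher number from compound 3 to compound 4 (0.48 log units; beyond the scatter), so the group at this position can move the number beyond the scatter. The move comes with no change in two counts, since (2-phenylethenyl)sulfonyl and (2-methoxyphenyl)carbamoyl each hold 11 heavy atoms and one six-membered aromatic ring of carbon only, while the entering group has 1 hydrogen-bond donor where the leaving group has 0. Nothing measured here explains the step.

Still open, as far as these compounds go, is whether the step follows the carbamoyl link or the methoxy group on the aromatic ring, a question that a plain phenylcarbamoyl or a (2-methoxyphenyl)sulfonyl group on the same nitrogen would help to separate. Also open, from the compounds shown here alone, is how an ethenylsulfonyl group would read on the core of compound 3, as compound 1 and compound 2 carry that group but also differ from compound 3 in other places.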